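Maximal electroshock notes: methyl to trifluoromethyl step

A few compounds are considered here, and "the series" means these few. Any claim that something is new, unique, unknown or untested is made for them only; others in the source may bear on it.

Measured:
compound 1 `CC1(c2ccccc2)CC(=O)N(CC(=O)N2CCN(c3ccccc3F)CC2)C1=O` — "not active" (no number reported)
compound 2 `Cc1cccc(N2CCN(C(=O)CN3C(=O)CC(C)(c4ccccc4)C3=O)CC2)c1` — 300 mg/kg

Among the measured compounds shown here, in a functional assay on the whole organism (strain CD-1) with Mus musculus as the target, in the maximal electroshock model, with a stated time of 2 h (a higher number here means that more compound is needed for the effect, a lower number that less compound is needed), compound 2 gives 300 mg/kg, the only number in hand for the series. Compound 1 gave "not active" (no number reported), with no number reported. Compound 3 `CC1(c2ccccc2)CC(=O)N(CC(=O)N2CCN(c3cccc(C(F)(F)F)c3)CC2)C1=O` differs from compound 2 as trifluoromethyl in place of methyl on an aromatic carbon. For the measured compounds named here, no measured pair differs in one place, so the size of such a step is not known from these compounds; a shift within the usual scatter, in either direction, is expected. Compound 3 is expected to give 300 mg/kg, in the range 100 mg/kg to 600 mg/kg. The expected step is no change at the digits printed from compound 2 to compound 3 (within the scatter), no larger than the scatter.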

Compound 3, minimum effective dose: 300 mg/kg
Compound 3: the middle estimate sits on the measured number at the digits printed; measured number inside the range.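

Among the compounds shown here, the first one-place step can now be read: in this assay, the change from 3-methylphenyl to 3-(trifluoromethyl)phenyl gives no change at the digits printed from compound 2 to compound 3 (within the scatter) in the minimum effective dose. This position therefore accepts trifluoromethyl in place of methyl, with one heavy atom replaced by four, without a step beyond the scatter. Nothing available explains this result.

As far as these compounds go, how an amine, a carboxylic acid or a longer chain would read at this position remains open. So does whether trifluoromethyl would give the same result elsewhere on the ring.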